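Compound 3: between its two neighbours?

The source may hold more compounds than are shown below. What is called first, only, known or untested is meant among the compounds shown, and "the series" means these compounds.

Compound 1 `O=c1c(S(=O)(=O)c2ccc(F)cc2F)cc2cnc(Nc3ccc4[nH]ccc4c3)nc2n1CC1CCCC1` gives 10000 nM
Compound 2 `O=c1c(S(=O)(=O)c2ccc(F)cc2F)cc2cnc(Nc3ccc4[nH]ccc4c3)nc2n1C1CC1` gives 500 nM

Among the compounds with values here, both values come from a functional assay on DU-145 cells (Homo sapiens) for inhibition, read by trypan blue exclusion, with a stated time of 72 h (a lower number here means a stronger inhibitor, a higher number a weaker inhibitor), and they are the only numbers so far. Compound 2 has the lower number of the two at 500 nM and so is the stronger inhibitor here, with compound 1 higher by a gap beyond the scatter. Compound 3 `O=c1c(S(=O)(=O)c2ccc(F)cc2F)cc2cnc(Nc3ccc4[nH]ccc4c3)nc2n1CC1CC1` keeps the shared core and changes one group (cyclopropylmethyl in place of cyclopropyl on an aromatic nitrogen). Cyclopropylmethyl stands in place of cyclopropyl on an aromatic nitrogen. Within the data shown here, one measured step bears on this, at the same nitrogen, and it is large (a 20-fold lower number from compound 1 to compound 2 (1.30 log units; beyond the scatter)). In that step cyclopropyl replaced cyclopentylmethyl, so ring and link changed together, and the data do not separate the two. Compound 3 keeps the ring of compound 2 and gains the methyl link of compound 1. Compound 1 at 10000 nM marks the high end, so a moderate rise in this assay is expected, leaving compound 3 nearer to compound 2. The expected size is a 3.0-fold higher number from compound 2 to compound 3 (0.48 log units; beyond the scatter) and no more than a rough guess. For compound 3 the estimate is 1500 nM (range 400 nM to 6000 nM).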

Compound 3, half-maximal inhibitory concentration: 1000 nM
Compound 3: the middle estimate sits 1.5-fold (0.18 log units) above what was measured, within the range that was stated.
By their numbers in this assay, from the lowest: compounds 2 and 3 (each within the scatter of the next); then compound 1.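

In this assay, adding only the methyl link to the cyclopropyl group on the aromatic nitrogen gives a 2.0-fold higher number from compound 2 to compound 3 (0.30 log units; within the scatter), so this change alone produces no difference that can be told apart from ordinary repeat variation. With the link kept in place, exchanging the ring gives a 10-fold lower number from compound 1 to compound 3 (1.00 log units; beyond the scatter), a clear effect that isolates the ring as a contributor, something the earlier pair could not do because ring and link changed together there. Nothing available explains why the cyclopentyl ring goes with the weaker result at this position.

The compounds shown leave open how the number changes across the ring sizes in the gap, such as with cyclobutylmethyl, and whether any ring is needed at all, as a plain ethyl group would show. They also leave open what a chain ending in an amine or a carboxylic acid would do on this nitrogen, and whether the ring effect seen here would hold with a different group elsewhere on the shared core.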